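Cytotoxicity notes on the shared core, dimethylamino removal

The source may report more compounds than this note shows. Statements on the series, on what has been measured and on what is new or still open speak of the compounds shown alone.

Measured so far:
compound 1, `O=C(Nc1cc(-c2nc3ccccc3s2)ccc1F)c1cc([N+](=O)[O-])ccc1Cl`, > 25000 nM
compound 2, `Cc1ccc(-c2nc3ccccc3s2)cc1NC(=O)c1cc([N+](=O)[O-])c(N(C)C)cc1Cl`, > 25000 nM

In an ADME assay on HepG2 cells (Homo sapiens) for cytotoxicity, with a stated time of 72 h (on this read-out lower numbers stand for an effect already at smaller amounts and higher numbers for an effect only at larger amounts of compound), compound 1 reaches only a limit of the assay, > 25000 nM. In this assay compound 2 likewise gives only a limit, > 25000 nM. Compound 2 therefore stands at the top of the numbers shown, and the two values do not separate from each other; both sit at the limit of > 25000 nM in this assay, at which 2 of the 2 values shown sit.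

Compound 3, `Cc1ccc(-c2nc3ccccc3s2)cc1NC(=O)c1cc([N+](=O)[O-])ccc1Cl`, is not yet measured in this assay. It differs from compound 2 in one place: hydrogen in place of dimethylamino on an aromatic carbon. The group that leaves sits ortho to the nitro group, meta to the chloro group and para to a large group.

Within the data shown here, no measured step gives a size for this change. With both measured values at the limit, the expected step from compound 2 to compound 3 in this assay is a step that the limit leaves unreadable from compound 2 to compound 3, that is, none beyond the scatter, because compound 2 itself sits at the limit of > 25000 nM in this assay, at which 2 of the 2 values shown sit. Compound 3 is accordingly expected to come out near 30000 nM, with a range of 10000 nM to 100000 nM, most likely reported again as a limit.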

Compound 3, half-maximal effective concentration: > 14000 nM
Compound 3: only a limit was reported; the forecaster's own chance of this, stated with the estimate: 80%; the middle value does not contradict the limit.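

In this assay compound 1, compound 2 and compound 3 each give only a limit, so neither the change from compound 2 to compound 3 nor that from compound 1 to compound 3 can be read as a step. The compounds shown leave open at what concentration any of them reaches a half-maximal cytotoxic effect.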